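Enlarging the Hydroxy Ring on a Shared Kinase Inhibitor Core

The compounds below may be only part of what the source reports. "The series", "measured", "known", "first", "only" and "open" are said of these compounds alone.

Compound 1 `N#Cc1cnc(NCc2cnccc2C(F)(F)F)cc1N[C@H]1C[C@H](O)C1` is examined in an assay on isolated protein for inhibition of protein kinase C theta type (Homo sapiens), read by TR-FRET, with a stated time of 2 h (on this read-out higher numbers stand for weaker inhibition and lower numbers for stronger inhibition), and gives 900 nM, the highest of the three numbers recorded so far. Compound 3 `N#Cc1cnc(NCc2cncnc2OCC(F)F)cc1N[C@H]1CC[C@@H](O)CC1` gives 90 nM in this assay, and compound 2 `N#Cc1cnc(NCc2ccccc2C(F)(F)F)cc1N[C@H]1CC[C@@H](C(N)=O)CC1` gives 20 nM; both lie beyond the scatter from compound 1, although each also differs from it in more than one place. Compound 4 `CC1(C)C[C@H](Nc2cc(NCc3cnccc3C(F)(F)F)ncc2C#N)CC[C@@H]1O` has not yet been measured. It departs from compound 1 at a single spot: 4-hydroxy-3,3-dimethylcyclohexyl in place of 3-hydroxycyclobutyl on a nitrogen on an aromatic ring. Both compound 2 and compound 3 bear a six-membered non-aromatic ring on that nitrogen, and both show lower numbers than compound 1. The step from compound 1 to compound 4 is expected to be a 6.0-fold lower number from compound 1 to compound 4 (0.78 log units; beyond the scatter), toward stronger inhibition. Compound 4 is therefore estimated to give 150 nM in this assay, within 40 nM to 500 nM.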

Compound 4, half-maximal inhibitory concentration: 7 nM
Beside the measured number, compound 4's estimate is 21-fold (1.33 log units) above it; measured number outside the range, below it.
By their numbers in this assay, from the lowest: compound 4; then compound 2; then compound 3; then compound 1.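

With the rest of the molecule unchanged, putting 4-hydroxy-3,3-dimethylcyclohexyl in place of 3-hydroxycyclobutyl on this nitrogen gives a 130-fold lower number from compound 1 to compound 4 (2.11 log units; beyond the scatter) in this assay. This shows that the group at this position can by itself shift the number strongly, which compound 2 and compound 3 could not show, as each also differs elsewhere. No measured evidence here accounts for the size of the step.

Ring size and the two methyl groups changed together, so their shares remain unseparated. Also open, from the compounds shown here alone, is how an amine in place of the hydroxy group on the ring would read.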